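The compounds below may be only part of what the source reports. "The series", "measured", "known", "first", "only" and "open" are said of these compounds alone.

Working notes on the series. Compound 1 `N#CCCCn1c(Cn2c(=O)n(-c3ccc(C(=O)NC4CC4)cc3)c3ccncc32)cc2cc(Cl)ccc21` is the parent of the step followed here. In an ADME assay on HeLa cells (Homo sapiens) for cytotoxicity, read by ATP content, with a stated time of 3 days (on this read-out lower numbers stand for higher toxicity in this test and higher numbers for lower toxicity in this test), compound 1 gives > 50000 nM, which is a limit of the assay and not a number. Compound 2 `CS(=O)(=O)CCCn1c(Cn2c(=O)n(CC3CC3)c3ccncc32)cc2cc(Cl)ccc21` gives > 50000 nM in this assay, again a limit. Compound 3 `O=c1n(Cc2nc3nc(Cl)ccc3n2CCCCF)c2cnccc2n1C1CC1` gives > 50000 nM in this assay, also a limit. So compound 1 stands where every value so far stands: the limit of > 50000 nM in this assay, at which 3 of the 3 values shown sit.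

Compound 4 `N#CCCCn1c(Cn2c(=O)n(-c3ccncc3)c3ccncc32)cc2cc(Cl)ccc21` carries the change (pyridin-4-yl in place of 4-(cyclopropylcarbamoyl)phenyl on an aromatic nitrogen). Going by the values given here, no step between measured compounds is known, so no direction can be drawn from the numbers. The step from compound 1 to compound 4 is expected to be none beyond the scatter, a step that the limit leaves unreadable from compound 1 to compound 4. Compound 4 is therefore estimated at 60000 nM, with a range from 30000 nM to 150000 nM, and most likely another limit.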

Compound 4, half-maximal cytotoxic concentration: > 50000 nM
Compound 4: a limit, no number; the forecaster's own chance of this, stated with the estimate: 75%; the middle value is on the limit's open side.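

No step can be read from compound 1 to compound 4, as both values are limits and not numbers: the limit of > 50000 nM in this assay, at which 4 of the 4 values shown sit. The compounds shown leave open whether any change to the shared core gives a measurable value in this assay.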